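The compounds below may be only part of what the source reports. "The series", "measured", "known", "first", "only" and "open" are said of these compounds alone.

Going by the values given here, compound 1, `Cc1cc(C)cc(S(=O)(=O)c2c(C(=O)N[C@@H]3CCN(Cc4cccnc4)C3)[nH]c3ccc(Cl)cc23)c1`, is the only member of this small set that gives an actual number in an ADME assay on MT4 cells (Homo sapiens) for cytotoxicity, read by MTT assay, with a stated time of 5 days; on this read-out lower numbers stand for higher toxicity in this test and higher numbers for lower toxicity in this test: compound 1 gives 36500 nM. The other two values are limits of the measurement rather than numbers. Compound 2, `Cc1cc(C)cc(S(=O)(=O)c2c(C(=O)NC3CN(Cc4ccccc4C#N)C3)[nH]c3ccc(Cl)cc23)c1`, reaches only the limit > 234000 nM. Compound 3, `CCS(=O)(=O)NC(=O)c1[nH]c2ccc(Cl)cc2c1S(=O)(=O)c1cc(C)cc(C)c1`, reaches only the limit > 283000 nM, as described by the limit of > 283000 nM in this assay, at which 1 of the 3 values shown sits.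

One measured step helps here. Going from compound 1 to compound 3 means ethylsulfonyl in place of 1-((pyridin-3-yl)methyl)pyrrolidin-3-yl on an amide-type nitrogen, and it brings an at least 7.7-fold higher number from compound 1 to compound 3 (0.88 log units; beyond the scatter), so the cells tolerated compound 3 far better.

Compound 4, `Cc1cc(C)cc(S(=O)(=O)c2c(C(=O)NS(=O)(=O)C(F)(F)F)[nH]c3ccc(Cl)cc23)c1`, differs from compound 1 in much the same spot: (trifluoromethyl)sulfonyl in place of 1-((pyridin-3-yl)methyl)pyrrolidin-3-yl on an amide-type nitrogen. Like compound 3, compound 4 carries a sulfonyl group on that nitrogen instead of the ring-bearing group. Because the comparable step an at least 7.7-fold higher number from compound 1 to compound 3 (0.88 log units; beyond the scatter) was large and toward lower toxicity, a similar direction is expected for compound 4, with the result likely to sit at a limit. The expected step is a 5.5-fold higher number from compound 1 to compound 4 (0.74 log units; beyond the scatter). Compound 4 is therefore estimated at 200000 nM, within a range from 60000 nM to 320000 nM.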

Compound 4, half-maximal cytotoxic concentration: 141000 nM
Compound 4: the middle estimate sits 1.4-fold (0.15 log units) above what was measured, and the stated range covers the measured number.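

Swapping the ring-bearing group for (trifluoromethyl)sulfonyl brings a 3.9-fold higher number from compound 1 to compound 4 (0.59 log units; beyond the scatter), so this change now has a true size in this assay, and with ethyl and trifluoromethyl alike, a sulfonyl group on this amide-type nitrogen gives a higher number than the ring-bearing group. Changing ethyl to trifluoromethyl on the sulfonyl sulfur brings an at least 2.0-fold lower number from compound 3 to compound 4 (0.30 log units; that floor lies within the scatter), so how much the group on the sulfur matters remains uncertain. Compound 3 offers only a limit, not a number, for this comparison: the limit of > 283000 nM in this assay, at which 1 of the 4 values shown sits.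

On these data alone, it remains open whether the higher numbers come from losing the 1-((pyridin-3-yl)methyl)pyrrolidin-3-yl group or from gaining the sulfonyl group. A plain primary amide or a simple methylsulfonyl group at this place could help separate those two effects.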